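The source may report more compounds than this note shows. Statements on the series, on what has been measured and on what is new or still open speak of the compounds shown alone.

Measured compounds:
compound 1, `CCN(CC)CCCNc1nc(-c2ccc(NC(=O)Nc3ccccc3)cc2)nc2ccsc12`: in a functional assay on NCI-H460 cells (Homo sapiens) for cytotoxicity, read by MTT assay, with a stated time of 72 h (a higher number here means a weaker inhibitor, a lower number a stronger inhibitor), compound 1 gives 680 nM
compound 2, `CCN(CC)CCCNc1nc(-c2ccc(NC(=O)Nc3ccc(Cl)cc3)cc2)nc2ccsc12`: in this assay compound 2 gives 81 nM
compound 3, `CCN(CC)CCNc1nc(-c2ccc(NC(=O)Nc3ccccc3Cl)cc2)nc2c(Cl)c(Cl)sc12`: in this assay compound 3 gives 460 nM

Compound 1 and compound 2 differ in one place only, (chloro in place of hydrogen on an aromatic carbon), and that single change produced an 8.4-fold lower number from compound 1 to compound 2 (0.92 log units; beyond the scatter). Compound 3 is built on a different core; the difference between its core and the core of compound 1 is not broken down here. Compound 3 and compound 1 give numbers within the usual scatter of each other, while compound 2 gives the lower number of the three, beyond the scatter from compound 3.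

Compound 4, `CCN(CC)CCNc1nc(-c2ccc(NC(=O)Nc3ccc(Cl)cc3Cl)cc2)nc2c(Cl)c(Cl)sc12`, differs from compound 3 by chloro in place of hydrogen on an aromatic carbon. Going by the values given here, this is the same kind of change as the one from compound 1 to compound 2, though not the same: in compound 4 the entering chloro sits meta to a chloro group as well as para to a large group, whereas in compound 2 it sits only para to a large group, and the core is that of compound 3. Among the compounds with values here, with two examples of this kind of change in all, the earlier one is the only guide.

The expectation for compound 4 rests on the gain seen in an 8.4-fold lower number from compound 1 to compound 2 (0.92 log units; beyond the scatter) applied to compound 3's 460 nM, tempered for the changed surroundings, and is a 3.5-fold lower number from compound 3 to compound 4 (0.55 log units; beyond the scatter). In this assay compound 4 is therefore estimated at 130 nM, expected between 50 nM and 350 nM.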

Compound 4, half-maximal inhibitory concentration: 1300 nM
Compound 4: middle estimate off by 10-fold (1.00 log units), on the low side, and the stated range ends below it.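

Taking 2-chlorophenyl to 2,4-dichlorophenyl in this assay gave a 2.8-fold higher number from compound 3 to compound 4 (0.45 log units; beyond the scatter), so the gain seen with this kind of change on the core of compound 1 did not recur on the core of compound 3. Chloro in place of hydrogen on this aromatic ring therefore cannot be carried from one core to the other in this series as a fixed increment, in either size or direction: the same change on two cores in this assay, an 8.4-fold lower number (0.92 log units; beyond the scatter) from compound 1 to compound 2 and a 2.8-fold higher number (0.45 log units; beyond the scatter) from compound 3 to compound 4, 24-fold (1.38 log units) apart, beyond the scatter of two such steps

This does not show that the core alone sets the outcome, since the entering chloro in compound 4 sits meta to a chloro group and para to a large group, whereas in compound 2 it sits only para to a large group, and a single pair on each core cannot separate these two differences.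

Open, as far as these compounds go, is whether the same chloro would lower the number on the core of compound 3 when the ring carries no other chloro, and whether a 2-chlorophenyl starting point would reverse the step on the core of compound 1. Also open, from the compounds shown here alone, is whether a methyl or methoxy group entering at the same place would follow compound 2 or compound 4.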